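Epoxyquinone core: stereochemistry unassigned, cytotoxicity on TE-8 cells

The source may hold more compounds than are shown below. What is called first, only, known or untested is meant among the compounds shown, and "the series" means these compounds.

Measured so far:
- compound 1, `CC(C)CC(=O)[C@@H]1O[C@@]12C(=O)C=C(Cc1ccccc1)NC2=O`: > 100000 nM
- compound 2, `CC1=CC(=O)[C@@]2(O[C@H]2C(=O)CC(C)C)C(=O)N1`: "not determined" (no result reported)

Compound 1 carries a benzyl group on the shared core, and in a functional assay on TE-8 cells (Homo sapiens) for cytotoxicity, read by WST assay, with a stated time of 48 h (on this read-out lower numbers stand for stronger inhibition and higher numbers for weaker inhibition), compound 1 gives only > 100000 nM, which is a limit of the assay and not a number. Compound 2, the smaller analogue with a methyl in place of the benzyl, has no reported result in this assay, so it stands nowhere on the numbers shown; the only value available in the set is the limit of compound 1, (the limit of > 100000 nM in this assay, at which 1 of the 2 values shown sits).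

Compound 3, `CC1=CC(=O)C2(OC2C(=O)CC(C)C)C(=O)N1`, is the same material as compound 2 with the stereocentres left unassigned: the two compounds have the same atoms and bonds; at least one stereo element is drawn with a configuration in one of them and without one in the other: 2 of 2 stereo elements differ; a stereocentre at a saturated ring carbon is drawn R in compound 2 and without a configuration in compound 3; a stereocentre at a saturated ring carbon is drawn R in compound 2 and without a configuration in compound 3. As no difference in atoms or bonds exists, no step beyond the usual scatter in this assay is expected between compound 2 and compound 3, but compound 2 offers no anchor number.

Resting on compound 1 alone, compound 3 is estimated at 100000 nM, with a range of 20000 nM to 300000 nM.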

Compound 3, half-maximal inhibitory concentration: 21600 nM
The estimate for compound 3 lay 4.6-fold (0.67 log units) above the measured number; the measured number falls inside the stated range.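

No step can be read between compound 2 and compound 3: compound 3 gives 21600 nM in this assay, while compound 2 offers no number to set against it. The compounds shown leave open whether cytotoxicity depends on the only thing separating this pair: the fact that one of compounds 2 and 3 is drawn with a defined configuration and the other without, at the place where they differ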